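A few compounds are considered here, and "the series" means these few. Any claim that something is new, unique, unknown or untested is made for them only; others in the source may bear on it.

Compound 1 `CC(C(=O)NCc1ccc(C(F)(F)F)cc1N1CCCCCCC1)c1ccc(NS(C)(=O)=O)c(F)c1` is the starting point. Going by the values given here, in an assay on CHO cells for antagonist activity at transient receptor potential cation channel subfamily V member 1 (Homo sapiens), read by FLIPR (on this read-out higher numbers stand for weaker inhibition and lower numbers for stronger inhibition), compound 1 gives 2.8 nM, the second highest of the three numbers known here. Compound 2 `CC(C(=O)NCc1ccc(C(F)(F)F)cc1N1CCN(C2CCCCC2)CC1)c1ccc(NS(C)(=O)=O)c(F)c1` gives 13.8 nM, and compound 3 `CCCCSc1cc(C(F)(F)F)ccc1CNC(=O)C(C)c1ccc(NS(C)(=O)=O)c(F)c1` gives 1.9 nM. Among the measured pairs, the step of a 4.9-fold higher number from compound 1 to compound 2 (0.69 log units; beyond the scatter) is the largest, the step of a 1.5-fold lower number from compound 1 to compound 3 (0.17 log units; within the scatter) stays within the scatter, and the step of a 7.3-fold lower number from compound 2 to compound 3 (0.86 log units; beyond the scatter) runs back toward stronger inhibition.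

Compound 4 `CCCCCCSc1cc(C(F)(F)F)ccc1CNC(=O)C(C)c1ccc(NS(C)(=O)=O)c(F)c1` has not yet been measured. It differs from compound 1 by a group of 7 heavy atoms (6 carbon, 1 sulfur; no ring) in place of a group of 8 heavy atoms (7 carbon, 1 nitrogen; one eight-membered non-aromatic ring with 1 hetero atom), on an aromatic carbon. The closest guide is the change from compound 1 to compound 3, where a shorter chain of the same kind, butylsulfanyl, took the place of the same ring-bearing group and gave a 1.5-fold lower number from compound 1 to compound 3 (0.17 log units; within the scatter). Among the compounds with values here, a longer chain in that position has no measured precedent here, so the step is expected to be small: a 1.1-fold lower number from compound 1 to compound 4 (0.05 log units; within the scatter), probably within the scatter. Compound 4 is therefore expected to give about 2.5 nM, with a likely range from 0.8 nM to 8 nM.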

Compound 4, inhibition constant: 1.8 nM
Estimate against measurement, compound 4: 1.4-fold (0.14 log units) above; the measured number falls inside the stated range.
By their numbers in this assay, from the lowest: compounds 4, 3 and 1 (each within the scatter of the next); then compound 2.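

In this assay, going from butylsulfanyl to hexylsulfanyl at this position gives a 1.1-fold lower number from compound 3 to compound 4 (0.02 log units; within the scatter), so the two chains cannot be told apart here. Hexylsulfanyl also stays within the scatter of the eight-membered ring group of compound 1, at a 1.6-fold lower number from compound 1 to compound 4 (0.19 log units; within the scatter), yet it keeps a clear gap from the 4-cyclohexylpiperazin-1-yl group, at a 7.7-fold lower number from compound 2 to compound 4 (0.88 log units; beyond the scatter), so compound 2 alone stands apart among the four compounds. Nothing measured here explains why these different groups give such similar numbers.

On these data alone, it remains open whether a longer chain such as octylsulfanyl, or a hexyl chain ending in an amine or a carboxylic acid, would keep numbers like these. As far as these compounds go, it is also open whether the sulfur itself matters, a question that hexyloxy, with oxygen in its place, would test.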